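This account rests on a few compounds, and the source may have more. Where it says the series, first, only, none or still open, it means among the compounds named here.

Compound 3 `CCCCSC(=S)C1=C(Nc2ccc(Cl)cc2)CC(C)(C)CC1=O` is one of three compounds tested in a functional assay on PBMC cells (Homo sapiens) for inhibition, read by ELISA, with a stated time of 18 h; a lower number here means a stronger inhibitor, a higher number a weaker inhibitor. In this assay compound 3 gives > 20 ug/mL, which is a limit of the assay rather than a number. Compound 1 `CCCCSC(=S)C1=C(Nc2ccc(Cl)cc2Cl)CC(C)(C)CC1=O` gives > 20 ug/mL, also a limit. Compound 2 `CC1(C)CC(=O)C(C(=S)SCc2ccccc2)=C(Nc2ccc(Cl)cc2Cl)C1` gives > 20 ug/mL, likewise a limit. All three stand together because of the limit of > 20 ug/mL in this assay, at which 3 of the 3 values shown sit. The steps a step that the two limits leave unreadable from compound 1 to compound 2 and a step that the two limits leave unreadable from compound 1 to compound 3 therefore cannot be sized. Compound 4 `CC1(C)CC(=O)C(C(=S)SCCO)=C(Nc2ccc(Cl)cc2)C1` differs from compound 3 by hydroxy in place of ethyl on a saturated chain carbon, two bonds along the chain from a sulfur. Among the compounds with values here, no measured step bears readably on this change, so the numbers give no direction for it, and a further limit is the most plausible outcome. Compound 4 is expected to give 30 ug/mL, with a range from 8 ug/mL to 100 ug/mL. The expected step is a step that the limit leaves unreadable from compound 3 to compound 4.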

Compound 4, half-maximal inhibitory concentration: > 20 ug/mL
Compound 4: no number, only a limit; the forecaster's own chance of this, stated with the estimate: 75%; the middle value lies beyond the limit too.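

Within the data shown here, compound 3 and compound 4 each give only a limit, not a number, so no step between them can be read: the limit of > 20 ug/mL in this assay, at which 4 of the 4 values shown sit. The compounds shown leave open how strongly any of them inhibits in this assay, and which change to the shared core would give a readable number.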